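Nitro for Amino on a Triazole Acetamide Core

This account rests on a few compounds, and the source may have more. Where it says the series, first, only, none or still open, it means among the compounds named here.

Three compounds built on one shared core were tested in an ADME assay on cells (spleen, Mus musculus, strain C57BL/6) for inhibition, read by flow cytometry and propidium iodide staining, with a stated time of 24 h, at 37 degrees C; on this read-out lower numbers stand for an effect already at smaller amounts and higher numbers for an effect only at larger amounts of compound. Compound 1 `Nc1cccc(-c2cn(CC(=O)NCc3ccccc3)nn2)c1` gives 800 uM in this assay. Compound 2 `Nc1ccc(-c2cn(CC(=O)NCc3ccccc3)nn2)cc1` differs from compound 1 only in where the amino group sits on the benzene ring, compound 1 carrying (3-aminophenyl in place of 4-aminophenyl on an aromatic carbon); in this assay compound 2 gives 1240 uM, so the step is a 1.6-fold higher number from compound 1 to compound 2 (0.19 log units; within the scatter). Compound 3 `O=C(Cn1cc(-c2ccc([N+](=O)[O-])cc2)nn1)NCc1ccccc1` gives 800 uM in this assay. The change from compound 2 to compound 3 is nitro in place of amino on an aromatic carbon, and it brought a 1.6-fold lower number from compound 2 to compound 3 (0.19 log units; within the scatter). Compound 1 and compound 3 thus stand at the same number, and all three values lie within the usual scatter of one another, so no ordering among them can be claimed.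

Compound 4 `O=C(Cn1cc(-c2cccc([N+](=O)[O-])c2)nn1)NCc1ccccc1` has not yet been measured. It differs from compound 1 by nitro in place of amino on an aromatic carbon. Among the measured compounds shown here, this is the same kind of change as the one from compound 2 to compound 3, with one difference in its surroundings: in compound 3 the nitro group stands para to a large group, in compound 4 it stands meta to a large group.

Compound 4 is expected to give about 600 uM in this assay. The expected step is a 1.3-fold lower number from compound 1 to compound 4 (0.12 log units; within the scatter), because the same kind of change in compound 2 gave a 1.6-fold lower number from compound 2 to compound 3 (0.19 log units; within the scatter). For the measured compounds named here, with only one prior example, the estimate for compound 4 is held to a range from 250 uM to 1500 uM.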

Compound 4, concentration for half-maximal effect: > 2000 uM
Compound 4 was reported as a limit (the forecaster's own chance of this, stated with the estimate: 10%); middle value at least 3.3-fold (0.52 log units) away from the limit.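

In this assay, nitro in place of amino on an aromatic carbon gives an at least 2.5-fold higher number from compound 1 to compound 4 (0.39 log units; beyond the scatter), so the change did not carry over in the same way from one core to the other: the same change on two cores in this assay, a 1.6-fold lower number (0.19 log units; within the scatter) from compound 2 to compound 3 and an at least 2.5-fold higher number (0.39 log units; beyond the scatter) from compound 1 to compound 4, at least 3.8-fold (0.58 log units) apart, beyond the scatter of two such steps. Compound 4 carries a limit and not a number, so its step has a known minimum but no known full size: the limit of > 2000 uM in this assay, at which 1 of the 4 values shown sits. The result shows that this one change cannot simply be transferred between these two cores, but with a single pair on each side it does not show why the two steps part, nor whether having the nitro group meta to a large group in compound 4 plays any role.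

The compounds shown leave open how other groups at this place would read in this assay, for example a nitrile, a carboxylic acid or a methylamine, and whether any of them would follow the step seen for compound 3 or the one seen for compound 4. On these data alone, it also remains open whether the two steps would stay apart on a core with a longer chain between the amide and its benzene ring.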